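The compounds below may be only part of what the source reports. "The series", "measured", "known", "first", "only" and "open" are said of these compounds alone.

Compound 2 `COc1ccc(NN=C(c2nc3ccccc3[nH]2)c2nc3ccccc3[nH]2)cc1` gives, in a functional assay on MCF7 cells (Homo sapiens) for cytotoxicity, read by MTT assay, with a stated time of 72 h (a lower number here means a stronger inhibitor, a higher number a weaker inhibitor), a value of 215000 nM, which is the highest of the two numbers recorded so far. Its nearest neighbour is compound 1 `Cc1ccc(NN=C(c2nc3ccccc3[nH]2)c2nc3ccccc3[nH]2)cc1`, whose number in this assay is 95800 nM; that single step, a 2.2-fold higher number from compound 1 to compound 2 (0.35 log units; beyond the scatter), is the only one yet measured and amounts to methoxy in place of methyl on an aromatic carbon. Compound 3 `O=[N+]([O-])c1ccc(NN=C(c2nc3ccccc3[nH]2)c2nc3ccccc3[nH]2)cc1` has not yet been tested. It differs from compound 2 by nitro in place of methoxy on an aromatic carbon, with the new group sitting para to a large group on the ring of carbon only. Going by the values given here, no measured step involves a nitro group, so nothing recorded speaks directly to this change; the one known step is modest and went from methyl to methoxy, not from methoxy to nitro. On that basis the change is expected to move the number in this assay little, with no direction that the data support beyond the scatter, so that a 1.4-fold lower number from compound 2 to compound 3 (0.16 log units; within the scatter) is the estimated step. Compound 3 is accordingly expected to give about 150000 nM in this assay, with a likely range from 50000 nM to 500000 nM.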

Compound 3, half-maximal inhibitory concentration: 94800 nM
Compound 3: the middle estimate sits 1.6-fold (0.20 log units) above what was measured; the range from low to high includes it.
By their numbers in this assay, from the lowest: compounds 3 and 1 (each within the scatter of the next); then compound 2.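

In this assay, the change from methoxy to nitro on an aromatic carbon, para to a large group, gives a 2.3-fold lower number from compound 2 to compound 3 (0.36 log units; beyond the scatter), so a second measured step at this position now leads away from the methoxy compound, this time with a replacement that is not methyl. Nitro in place of methyl gives a 1.0-fold lower number from compound 1 to compound 3 (0.00 log units; within the scatter), which lies within the scatter, so these two groups cannot be told apart here, although they differ in heavy atoms and hydrogen-bond acceptors; compound 2 is the weakest of the three, with its steps to both others printed as beyond the scatter, and this sets methoxy apart rather than ordering the groups along a single trend. No measurement offered here accounts for why methoxy stands apart from both methyl and nitro at this position.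

As far as these compounds go, whether methoxy is alone in this respect remains open, since an amine, a carboxylic acid, chlorine or a longer chain such as ethoxy at the same place could fall with either side or outside both. The three compounds also leave open whether any group at this position can take the number in this assay well away from the values seen so far, and whether these small differences hold on any other core.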